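Series notes: hydroxy-substituted amide partners, liver microsome stability

A few compounds are considered here, and "the series" means these few. Any claim that something is new, unique, unknown or untested is made for them only; others in the source may bear on it.

Among the measured compounds shown here, compound 1 `Cc1c(Cc2ccc(-c3ccn(C)n3)cc2)cc(C(=O)N[C@H]2CCCC[C@@H]2O)c(=O)n1C` is the first reference point. In an ADME assay on microsomes from liver (Homo sapiens) for metabolic stability (a lower number here means slower removal, a higher number faster removal of the compound), compound 1 gives 13 mL/min/kg. Compound 2 `Cc1cnc(C(=O)N[C@H]2CCOC[C@@H]2O)cc1Cc1ccc(-n2cccn2)cc1` carries a different core and a different aromatic substituent. In this assay compound 2 returns only a limit, < 8 mL/min/kg, so no number is available for it. For the measured compounds named here, that limit is the only statement about where compound 2 stands, and it sits at the limit of < 8 mL/min/kg in this assay, at which 1 of the 2 values shown sits, together with one of the two values recorded so far. Going by the values given here, no step between measured compounds can be traced, since compound 1 and compound 2 differ in more than one place.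

Compound 3 `Cc1cnc(C(=O)N[C@H]2CCCC[C@@H]2O)cc1Cc1ccc(-n2cccn2)cc1` is not yet measured. It differs from compound 2 in one place: 2-hydroxycyclohexyl in place of 3-hydroxyoxan-4-yl on an amide-type nitrogen. Among the compounds with values here, no measured step maps onto this change. Given that compound 2 is reported only as a limit, the step from compound 2 to compound 3 in this assay is expected to be upward, of moderate size, estimated as an at least 1.5-fold higher number from compound 2 to compound 3 (0.17 log units; that floor lies within the scatter). For compound 3 the expected value in this assay is 12 mL/min/kg, with a likely range from 6 mL/min/kg to 24 mL/min/kg.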

Compound 3, clearance: 20 mL/min/kg
Compound 3: middle estimate off by 1.7-fold (0.22 log units), on the low side; measured number inside the range.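

Among the compounds shown here, with the shared core and the aromatic substituent unchanged, compound 2 and compound 3 give the only one-place comparison so far: in this assay, 2-hydroxycyclohexyl in place of 3-hydroxyoxan-4-yl on an amide-type nitrogen gives an at least 2.5-fold higher number from compound 2 to compound 3 (0.39 log units; beyond the scatter). The read-out therefore responds to this position alone, which compound 1 and compound 2 could not show, since they differ in more than one place. The step can be read only as a floor, and its full size stays unknown, because one end of it is a limit and not a number: the limit of < 8 mL/min/kg in this assay, at which 1 of the 3 values shown sits.

Whether the same change carries over to the core of compound 1 stays open, since that compound already bears a hydroxycyclohexyl partner and no 3-hydroxyoxan-4-yl counterpart on that core is among the compounds shown. Also open, from the compounds shown here alone, is where a partner with an amine in the ring, in place of the oxygen of 3-hydroxyoxan-4-yl, would fall in this assay relative to these two groups.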